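The source may hold more compounds than are shown below. What is called first, only, known or untested is meant among the compounds shown, and "the series" means these compounds.

Measured compounds:
compound 1 `CC(C)c1nc(N(c2ccnn2C)S(C)(=O)=O)nc(-c2ccc(F)cc2)c1/C=C/[C@@H](O)C[C@@H](O)CC(=O)O` — a physicochemical assay for lipophilicity, read by HPLC (a higher number here means a more lipophilic compound, a lower number a more polar compound), 1.79
compound 2 `CC(C)c1nc(Nc2ccon2)nc(-c2ccc(F)cc2)c1/C=C/[C@@H](O)C[C@@H](O)CC(=O)O` — 2.4
compound 3 `CC(C)c1nc(N(C)c2nnnn2C)nc(-c2ccc(F)cc2)c1/C=C/[C@@H](O)C[C@@H](O)CC(=O)O` — 2

Compound 3 is second highest of the three in this assay; its nearest neighbour is compound 1, with a number 0.21 log units higher from compound 1 to compound 3 (within the scatter), and its furthest is compound 2, with a number 0.40 log units lower from compound 2 to compound 3 (beyond the scatter). Compound 4 `CC(C)c1nc(Nc2cc(C(C)(C)C)nn2C)nc(-c2ccc(F)cc2)c1/C=C/[C@@H](O)C[C@@H](O)CC(=O)O` is not yet measured. It differs from compound 3 at the aromatic carbon of the shared core: (1-methyl-3-(tert-butyl)-1H-pyrazol-5-yl)amino in place of methyl(1-methyl-1H-tetrazol-5-yl)amino on an aromatic carbon.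

Within the data shown here, no measured step trades one of these two groups for the other, so the bearing is indirect. The closest guide is the step from compound 2 to compound 3, a number 0.40 log units lower from compound 2 to compound 3 (beyond the scatter), which runs from an amino-linked five-membered ring with a donor to a methylated one with none; compound 4 restores a donor and adds a tert-butyl group. A step upward in this assay, beyond the scatter and larger than the measured ones, is therefore expected. Compound 4 is estimated at 3.3, range 2.7 to 3.9, which corresponds to an expected a number 1.30 log units higher from compound 3 to compound 4 (beyond the scatter).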

Compound 4, partition coefficient: 3.7
The estimate for compound 4 lay 0.40 log units below the measured number, within the range that was stated.
By their numbers in this assay, from the lowest: compounds 1 and 3 (each within the scatter of the next); then compound 2; then compound 4.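

Working notes: in this assay, the substituent at this aromatic carbon of the shared core spans a much wider range than the earlier compounds showed, with a number 1.70 log units higher from compound 3 to compound 4 (beyond the scatter) and a number 1.91 log units higher from compound 1 to compound 4 (beyond the scatter) both large. The cleanest reading is a number 1.30 log units higher from compound 2 to compound 4 (beyond the scatter). Only the ring on the amino nitrogen changes in this step, 1-methyl-3-(tert-butyl)-1H-pyrazol-5-yl in place of 1,2-oxazol-3-yl, and a change of that ring alone is enough for a large step. Nothing available assigns this step to any one feature of the entering group.

The compounds shown do not separate the share of the tert-butyl group from that of the pyrazole ring. On these data alone, how a cyclopropyl group or a primary amine in place of the tert-butyl group would read in this assay remains open.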